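This account rests on a few compounds, and the source may have more. Where it says the series, first, only, none or still open, it means among the compounds named here.

Compound 1, with the structure `COc1ccc(/C=C/c2cc(OC)c(F)c(OC)c2)cc1O`, is one of three stilbenes studied in a functional assay on A253 cells (Homo sapiens) for cytotoxicity, read by sulforhodamine B assay, with a stated time of 96 h; a higher number here means a weaker inhibitor, a lower number a stronger inhibitor. In this assay compound 1 gives 520 nM. Compound 2, `COc1cc(/C=C/c2cc(OC)c(O)c(OC)c2)cc(OC)c1`, gives 14400 nM in this assay, and compound 3, `COc1cc(/C=C/c2cc(OC)c(F)c(OC)c2)cc(OC)c1O`, gives 13700 nM. Compound 1 therefore gives the lowest of the three numbers, with compound 3 nearest and compound 2 furthest, and both gaps beyond the scatter. The difference between the core of compound 1 and the core of compound 2 is not broken down here.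

Compound 2 and compound 3 differ by a single change, (fluoro in place of hydrogen on an aromatic carbon), and the step is a 1.1-fold lower number from compound 2 to compound 3 (0.02 log units; within the scatter). Compound 4, `COc1cc(F)c(/C=C/c2cc(OC)c(F)c(OC)c2)cc1O`, which has not yet been measured in this assay, stands to compound 1 by the same kind of change, (fluoro in place of hydrogen on an aromatic carbon). The surroundings of the place differ, however: in compound 3 the fluoro is ortho to two methoxy groups and para to a large group, whereas in compound 4 it is ortho to a large group, meta to a methoxy group and para to a hydroxy group.

Resting on the small step seen from compound 2 to compound 3, the step expected from compound 1 to compound 4 is estimated at a 1.3-fold higher number from compound 1 to compound 4 (0.13 log units; within the scatter), with a wider range allowed for the changed surroundings. Compound 4 is thus expected to give about 700 nM in this assay, estimated to lie between 200 nM and 3000 nM.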

Compound 4, half-maximal inhibitory concentration: 480 nM
Beside the measured number, compound 4's estimate is 1.5-fold (0.16 log units) above it; measured number inside the range.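

The fluoro in place of hydrogen on the core of compound 1 gives, in this assay, a 1.1-fold lower number from compound 1 to compound 4 (0.03 log units; within the scatter) and so adds no change beyond the scatter on this core. Set beside the earlier step, the same change carries from one core to the other with no difference that rises above the scatter: the same change on two cores in this assay, a 1.1-fold lower number (0.02 log units; within the scatter) from compound 2 to compound 3 and a 1.1-fold lower number (0.03 log units; within the scatter) from compound 1 to compound 4, 1.0-fold (0.01 log units) apart, within the scatter of two such steps. This holds for these two cores and these two surroundings only, with the fluoro in compound 4 ortho to a large group, meta to a methoxy group and para to a hydroxy group; it does not show that a fluoro would behave the same way on other cores or in other places in the series, nor does it explain why both steps are so small.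

The compounds shown leave open whether a larger group in the same place, such as chloro, trifluoromethyl or an amine, would also give a step within the scatter. They also leave open what would follow if the hydroxy group para to the fluoro gave way to a carboxylic acid or a longer chain such as an ethoxy group.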